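Swapping the enone end groups on a fused core

The source may report more compounds than this note shows. Statements on the series, on what has been measured and on what is new or still open speak of the compounds shown alone.

Two compounds share a fused two-ring core carrying a 3,4-dimethoxyphenyl group and a phenyl group. Compound 1 `COc1ccc(-c2cc(/C=C/C(=O)c3cc(OC)c(OC)c(OC)c3)nc3cc(-c4ccccc4)nn23)cc1OC` and compound 2 `COc1ccc(-c2cc(C(=O)/C=C/c3ccc(Cl)cc3)nc3cc(-c4ccccc4)nn23)cc1OC` were both tested in an ADME assay on HEK293 cells (Homo sapiens) for antiproliferative activity, read by MTT assay, with a stated time of 24 h; a lower number here means a stronger inhibitor, a higher number a weaker inhibitor. Compound 2 gives 39100 nM, and compound 1 gives 35000 nM; the two lie within the scatter of each other, so neither can be called the stronger. Compound 3 `COc1ccc(-c2cc(/C=C/C(=O)c3ccc(C)cc3)nc3cc(-c4ccccc4)nn23)cc1OC` has not yet been measured in this assay. It differs from compound 2 in one place: 2-((4-methylphenyl)carbonyl)ethenyl in place of (2-(4-chlorophenyl)ethenyl)carbonyl on an aromatic carbon. Since compounds 1 and 2 sit so close, the step of a 1.0-fold lower number from compound 2 to compound 3 (0.01 log units; within the scatter) is expected to stay within the scatter. Compound 3 is expected near 38000 nM, between 15000 nM and 90000 nM.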

Compound 3, half-maximal inhibitory concentration: 62600 nM
For compound 3 the middle estimate is 1.6-fold (0.22 log units) below the measured one; the measured number falls inside the stated range.
By their numbers in this assay, from the lowest: compounds 1, 2 and 3 (each within the scatter of the next).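

In this assay, 2-((4-methylphenyl)carbonyl)ethenyl in place of (2-(4-chlorophenyl)ethenyl)carbonyl gives a 1.6-fold higher number from compound 2 to compound 3 (0.20 log units; within the scatter). With the enone direction held the same, 4-methylphenyl in place of 3,4,5-trimethoxyphenyl on the carbonyl carbon gives a 1.8-fold higher number from compound 1 to compound 3 (0.25 log units; within the scatter), so neither end-group change at this position produces a difference that can be told from scatter. Nothing measured here offers an explanation for these numbers. Still open, from the compounds shown here alone, is whether an end group carrying an amine or a carboxylic acid would give a number beyond the scatter from these three.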